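A few compounds are considered here, and "the series" means these few. Any claim that something is new, unique, unknown or untested is made for them only; others in the source may bear on it.

Of the compounds shown here, three have so far been measured in a functional assay on A2780 cells (Homo sapiens) for cytotoxicity, read by MTT assay, with a stated time of 24 h; a higher number here means a weaker inhibitor, a lower number a stronger inhibitor.
Compound 1, `CCCCC[C@@H](C[C@H](O)C[C@@H]1CC=CC(=O)O1)OC`, gives 35400 nM.
Compound 2, `CCCCC[C@@H](CCC[C@H]1CC=CC(=O)O1)OC`, gives 20600 nM.
Compound 3, `CCCCC[C@@H](C[C@@H](O)C[C@H]1CC=CC(=O)O1)OC`, gives 33700 nM.

Compound 2 has the lowest of these three numbers, yet its gap to compound 3 is only a 1.6-fold higher number from compound 2 to compound 3 (0.21 log units; within the scatter), and compound 1 lies no further off, so all three sit within the scatter of one another and none can be called stronger or weaker than the rest.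

The unmeasured compound 4, `CCCCC[C@H](CCC[C@H]1CC=CC(=O)O1)OC`, is related to compound 2 by the two compounds have the same atoms and bonds and differ only in configuration as drawn: 1 of 2 stereo elements differ; a stereocentre at a saturated chain carbon is drawn S in compound 2 and R in compound 4. Among the measured steps, only one speaks to a change of this kind: the step from compound 1 to compound 3, a 1.1-fold lower number from compound 1 to compound 3 (0.02 log units; within the scatter), is the relevant guide because of the fact that compounds 1 and 3 differ only in the configuration as drawn. There, even two stereocentres redrawn at once left the number essentially where it was. Within the data shown here, the single change of configuration that separates compound 4 from compound 2 is therefore expected to produce no step beyond the scatter, and the step is estimated as a 1.1-fold higher number from compound 2 to compound 4 (0.03 log units; within the scatter).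

Compound 4 is thus expected to give 22000 nM in this assay, with a likely range from 10000 nM to 50000 nM.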

Compound 4, half-maximal inhibitory concentration: 17100 nM
Compound 4: middle estimate off by 1.3-fold (0.11 log units), on the high side, and the stated range covers the measured number.
By their numbers in this assay, from the lowest: compounds 4, 2, 3 and 1 (each within the scatter of the next, the first and the last beyond it).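

In this assay, the step is a 1.2-fold lower number from compound 2 to compound 4 (0.08 log units; within the scatter), so redrawing this one saturated chain carbon leaves the number within the scatter. The earlier pair, compound 1 and compound 3, had shown this only for two other stereocentres redrawn together, one at a saturated chain carbon and one at a saturated ring carbon, so this is the first reading for this stereocentre, and it is also a reading of a single change on its own. The result describes a change of drawn configuration alone, with nothing added or removed, so the comparison is clean: the fact that compounds 2 and 4 differ only in the configuration as drawn

The compounds shown leave open whether this stereocentre would behave the same way in a compound that carries the hydroxy group, and whether either of the other two stereocentres would matter if redrawn singly. They also leave open what would happen with an amine or a carboxylic acid in place of that hydroxy group, or with a longer chain in place of the present one.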